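A few compounds are considered here, and "the series" means these few. Any claim that something is new, unique, unknown or untested is made for them only; others in the source may bear on it.

Compound 2 `COc1ccc(-c2cc(CO[C@H]3CC(=O)[C@@H]4OC[C@H]3O4)on2)cc1` belongs to a small set of three analogues built on a shared core. In a functional assay on MDA-MB-231 cells (Homo sapiens) for cytotoxicity, read by MTT assay, with a stated time of 48 h (a higher number here means a weaker inhibitor, a lower number a stronger inhibitor), compound 2 gives 21900 nM. Compound 1 `O=C1C[C@H](OCc2cn(C3CCCCC3)nn2)[C@H]2CO[C@@H]1O2` gives 24300 nM, and compound 3 `O=C1C[C@H](OCc2cc(-c3ccc([N+](=O)[O-])cc3)no2)[C@H]2CO[C@@H]1O2` gives 16500 nM. Among these three numbers compound 2 stands second highest, with compound 1 nearest and compound 3 furthest, and all three lie within the scatter of one another. Among the measured compounds shown here, the only single-point step in the set is a 1.3-fold lower number from compound 2 to compound 3 (0.12 log units; within the scatter). Compound 4 `O=C1C[C@H](OCc2cc(C3CCCCC3)no2)[C@H]2CO[C@@H]1O2` differs from compound 2 by cyclohexyl in place of 4-methoxyphenyl on an aromatic carbon. The step from compound 2 to compound 3 bears on this change insofar as it alters the same place, and it stayed within the scatter; compound 1, which also carries a cyclohexyl, shows a number within the scatter of compound 2. Nothing in the set points to a shift beyond the scatter, so the step of a 1.0-fold higher number from compound 2 to compound 4 (0.00 log units; within the scatter) is expected to be small. Compound 4 is therefore estimated at 22000 nM, within a range from 10000 nM to 45000 nM.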

Compound 4, half-maximal inhibitory concentration: 15800 nM
For compound 4 the middle estimate is 1.4-fold (0.14 log units) above the measured one; the range from low to high includes it.
By their numbers in this assay, from the lowest: compounds 4, 3, 2 and 1 (each within the scatter of the next).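

In this assay, among the compounds shown here, the step of a 1.4-fold lower number from compound 2 to compound 4 (0.14 log units; within the scatter) stays within the scatter, and it is the first change at this place that leaves the aromatic rings behind. Compounds 2 and 3 differed only in the group carried on the same six-membered aromatic ring, whereas compound 4 has a non-aromatic ring of carbon only and no hydrogen-bond acceptor in the entering group. Even this larger change at the position gives no shift beyond the scatter. No evidence is at hand that bears on this result. 

The compounds shown leave open whether an amine, a carboxylic acid or a longer chain at this place would move the number beyond the scatter. They also leave open whether any change to the carbonyl of the shared core would do so.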